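Trimming the Sulfonyl Substituent of Compound 1

This account rests on a few compounds, and the source may have more. Where it says the series, first, only, none or still open, it means among the compounds named here.

compound 1, `COc1ccccc1S(=O)(=O)Nc1ccc2oc(-c3ccccc3)nc2c1`: > 100000 nM
compound 2, `O=[N+]([O-])c1cc(S(=O)(=O)Nc2ccc(-c3nc4ccccc4o3)cc2)ccc1Cl`: 17000 nM
compound 3, `Cc1ccccc1S(=O)(=O)Nc1ccc(-c2nc3ccccc3o2)cc1`: 85000 nM

In an assay on cells for inhibition of HSP60/HSP10 (Homo sapiens), with a stated time of 60 min (a higher number here means a weaker inhibitor, a lower number a stronger inhibitor), compound 1 gives > 100000 nM, which is a limit of the assay and not a number. Compound 1 therefore stands at the limit of > 100000 nM in this assay, at which 1 of the 3 values shown sits, the weakest position among the values shown. Compound 2 gives 17000 nM and compound 3 gives 85000 nM. Compound 4, `CS(=O)(=O)Nc1ccc2oc(-c3ccccc3)nc2c1`, has not yet been measured; it differs from compound 1 by methyl in place of 2-methoxyphenyl on a sulfonyl sulfur. Within the data shown here, no step between measured compounds is known here. With compound 1 standing at the limit of > 100000 nM in this assay, at which 1 of the 3 values shown sits, the expected step that the limit leaves unreadable from compound 1 to compound 4 is none beyond the scatter. Compound 4 is expected to give about 150000 nM, between 50000 nM and 500000 nM, and may well return only a limit again.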

Compound 4, half-maximal inhibitory concentration: > 100000 nM
Compound 4: no number, only a limit; the forecaster's own chance of this, stated with the estimate: 70%; the middle value lies beyond the limit too.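

Compound 1 and compound 4 each return only a limit of the assay, so no step can be read between them: the limit of > 100000 nM in this assay, at which 2 of the 4 values shown sit. The compounds shown leave open whether methyl in place of 2-methoxyphenyl on a sulfonyl sulfur changes inhibition at all.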